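The compounds below may be only part of what the source reports. "The series", "measured", "known", "first", "only" and "open" are said of these compounds alone.

Of the compounds shown here, two of a shared core have been measured in an assay (Cricetulus griseus) for inhibition of aldehyde dehydrogenase, mitochondrial (Homo sapiens); on this read-out higher numbers stand for weaker inhibition and lower numbers for stronger inhibition. Compound 1 `NCCCCCCOc1ccc2c(=O)c(-c3ccc(O)cc3)coc2c1` gives 100 nM, and compound 2 `CCOC(=O)CCCCOc1ccc2c(=O)c(-c3ccc(O)cc3)coc2c1` gives 240 nM. Within the data shown here, the one step available, a 2.4-fold higher number from compound 1 to compound 2 (0.38 log units; beyond the scatter), concerns only the group at the far end of the chain attached to the oxygen on the aromatic ring. On the two numbers at hand compound 2 stands highest, with compound 1 a modest step lower.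

Compound 3 `CC(C)Oc1ccc2c(=O)c(-c3ccc(O)cc3)coc2c1` is not yet measured. It differs from compound 2 in one place: isopropyl in place of 4-(ethoxycarbonyl)butyl on an oxygen on an aromatic ring. Among the measured compounds shown here, no measured step removes the chain itself; the step from compound 1 to compound 2 only exchanges its terminal group and does not directly inform a change to a short isopropyl on the oxygen. The change therefore stands on its own, and compound 3 is expected to lie near compound 2 in this assay, with a step of a 1.2-fold lower number from compound 2 to compound 3 (0.08 log units; within the scatter) that is estimated to stay roughly within the usual scatter. For the measured compounds named here, compound 3 is accordingly estimated at 200 nM, with a range from 60 nM to 700 nM reflecting that no measured step bears closely on it.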

Compound 3, half-maximal inhibitory concentration: 80 nM
For compound 3 the middle estimate is 2.5-fold (0.40 log units) above the measured one; the range from low to high includes it.
By their numbers in this assay, from the lowest: compounds 3 and 1 (each within the scatter of the next); then compound 2.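

In this assay, the change at the oxygen on the aromatic ring shows that the long chain is not required for this level of inhibition: 4-(ethoxycarbonyl)butyl, with 9 heavy atoms including 2 oxygen atoms, gives way to isopropyl, with 3 heavy atoms and no hydrogen-bond acceptors, and the result is a 3.0-fold lower number from compound 2 to compound 3 (0.48 log units; beyond the scatter). The comparison with the amine-ended chain points the same way, since isopropyl in place of 6-aminohexyl gives a 1.3-fold lower number from compound 1 to compound 3 (0.10 log units; within the scatter), so on these values the terminal amine is not needed to reach the level of compound 1. Nothing available explains why the short group reads as it does, and no independent finding bears on this result.

The compounds shown leave open whether the higher number of compound 2 belongs to its ethyl ester end or to its chain as a whole, which a carboxylic acid at the chain end or an unsubstituted butyl chain would help to separate. They also leave open how far the group on this oxygen can shrink or grow, as with a methyl group, a free hydroxyl in place of the ether, or a cyclopentyl ring.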